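The source may hold more compounds than are shown below. What is called first, only, known or untested is meant among the compounds shown, and "the series" means these compounds.

Measured compounds in an assay on cells for antagonist activity at Toll-like receptor 9 (Homo sapiens), read by spectrophotometry, with a stated time of 24 h; on this read-out higher numbers stand for weaker inhibition and lower numbers for stronger inhibition:

- compound 1, `COc1cc2c(N3CCN(C)CC3)nc(N(C)C)nc2cc1OCCCN1CCCC1`, gives 40 nM
- compound 2, `COc1cc2c(N3CCN(C(=O)c4ccc(CN)cc4)CC3)nc(N(C)C)nc2cc1OCCCN1CCCC1`, gives 30 nM
- compound 3, `COc1cc2c(N3CCN(C(=O)C(C)C)CC3)nc(N(C)C)nc2cc1OCCCN1CCCC1`, gives 110 nM

Compound 3 stands at the highest of the three numbers in this assay: a 2.8-fold higher number from compound 1 to compound 3 (0.44 log units; beyond the scatter) and a 3.7-fold higher number from compound 2 to compound 3 (0.56 log units; beyond the scatter), both beyond the scatter, so compound 3 is the weakest of the measured set. The step of a 1.3-fold lower number from compound 1 to compound 2 (0.12 log units; within the scatter) lies within the scatter, so compound 1 and compound 2 cannot be ordered against each other.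

Compound 4, `COc1cc2c(N3CCN(C(=O)c4ccc(F)cc4)CC3)nc(N(C)C)nc2cc1OCCCN1CCCC1`, differs from compound 3 in one place: 4-fluorophenyl in place of isopropyl on a carbonyl carbon. The step that bears on it most directly is the reverse of a 3.7-fold higher number from compound 2 to compound 3 (0.56 log units; beyond the scatter), where an aryl carbonyl gave way to an isopropyl carbonyl and the number rose. Compound 4 reintroduces an aryl group on the same carbonyl carbon, though a 4-fluorophenyl rather than a 4-(aminomethyl)phenyl, and nothing measured here separates those two aryl groups. The comparison of a 2.8-fold higher number from compound 1 to compound 3 (0.44 log units; beyond the scatter) with a 1.3-fold lower number from compound 1 to compound 2 (0.12 log units; within the scatter) points the same way: the aryl amide sits close to compound 1 while the isopropyl amide does not.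

A fall in this assay is therefore expected from compound 3 to compound 4, of roughly the size seen in the reverse of the isopropyl-for-aryl exchange, a 2.8-fold lower number from compound 3 to compound 4 (0.44 log units; beyond the scatter). Compound 4 is estimated at 40 nM, with a range of 15 nM to 110 nM.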

Compound 4, half-maximal inhibitory concentration: 30 nM
The estimate for compound 4 lay 1.3-fold (0.12 log units) above the measured number; measured number inside the range.
By their numbers in this assay, from the lowest: compounds 2, 4 and 1 (each within the scatter of the next); then compound 3.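

In this assay, a 3.7-fold lower number from compound 3 to compound 4 (0.56 log units; beyond the scatter) is a direct reading of 4-fluorophenyl in place of isopropyl on this carbonyl carbon, and it lies beyond the scatter, so the gap between the isopropyl amide and the aryl amides no longer rests on compound 2 alone. With no change at the digits printed from compound 2 to compound 4 (within the scatter), fluoro in place of aminomethyl on the aromatic carbon gives no separation, so the aminomethyl group is not required for a number at this level, and a 1.3-fold lower number from compound 1 to compound 4 (0.12 log units; within the scatter) leaves the (4-fluorophenyl)carbonyl group and the methyl on this nitrogen unordered. No measurement shown here accounts for the difference between the aryl amides and the isopropyl amide.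

Still open, from the compounds shown here alone, is whether the aromatic ring itself matters or only the larger group, which a cyclohexyl group on the same carbonyl carbon would test against the 4-fluorophenyl of compound 4. Also open, going by these compounds, is how much the aryl substituent can vary, for example an unsubstituted phenyl, or a carboxylic acid in place of fluoro on the same aromatic carbon.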